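The source may hold more compounds than are shown below. What is called first, only, known or untested is meant among the compounds shown, and "the series" means these compounds.

Measured compounds in an ADME assay on RAW264.7 cells (Mus musculus) for cytotoxicity, read by MTT assay, with a stated time of 24 h; a higher number here means that more compound is tolerated, a lower number that less compound is tolerated:
- compound 1 `COc1ccc(C(=O)Nc2ccc(Cl)cc2F)c(OC)c1`: 13600 nM
- compound 2 `COc1ccccc1C(=O)Nc1ccc(I)cc1F`: > 40000 nM
- compound 3 `COc1ccc(C(=O)Nc2ccc(I)cc2F)c(O)c1`: 27600 nM

Compound 2 gives a value that is a limit of this assay and not a number (the limit of > 40000 nM in this assay, at which 1 of the 3 values shown sits). Among the two numbers that remain, compound 3 stands highest in this assay; its nearest neighbour is compound 1, whose number is lower by a margin beyond the usual scatter. For the measured compounds named here, compound 1 differs from compound 3 in two places at once, so no single step between measured compounds is available.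

Compound 4 `COc1ccc(C(=O)Nc2ccc(I)cc2F)c(OC)c1` has not yet been measured in this assay. It differs from compound 3 in one place: methyl in place of hydrogen on an oxygen on an aromatic ring — that is, hydroxy to methoxy, so that compound 4 carries the same methoxy pattern as compound 1 and differs from compound 1 only in iodine in place of chlorine.

With no measured step of this kind in the set, the expectation rests on compound 1 alone. A modest downward step is expected, a 1.5-fold lower number from compound 3 to compound 4 (0.19 log units; within the scatter), and it may well fall within the scatter. Compound 4 is estimated at 18000 nM, with a range from 8000 nM to 40000 nM, since compound 1 gives 13600 nM with the same methoxy in place.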

Compound 4, half-maximal cytotoxic concentration: > 40000 nM
Compound 4 gave a limit, no number (the forecaster's own chance of this, stated with the estimate: 15%); middle value at least 2.2-fold (0.34 log units) away from the limit.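

In this assay compound 4 sits at a limit and not at a number, as does compound 2, so the step between these two cannot be read: the limit of > 40000 nM in this assay, at which 2 of the 4 values shown sit.

At this oxygen, hydroxy to methoxy gives an at least 1.4-fold higher number from compound 3 to compound 4 (0.16 log units; that floor lies within the scatter), so the methyl shows no sign of lowering the tolerated concentration, though a real rise is not established either. For the compounds shown here, the clearer reading comes from the halogen, where iodo in place of chloro on an aromatic carbon gives an at least 2.9-fold higher number from compound 1 to compound 4 (0.46 log units; beyond the scatter); this is the first single change to be read beyond the scatter, and with the methoxy pattern held constant, it is the halogen that separates compound 1 from compound 4.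

On these data alone, with compound 4 at a limit, the true size of both readable steps in this assay stays unknown, as each gives only a floor. Also open, as far as these compounds go, is whether a larger change at this oxygen, such as a longer chain, or an amine or a carboxylic acid in its place, would bring the iodo series back to a number within the range of the assay.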